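Changing the Aromatic Ring on a Cytotoxic Series

A few compounds are considered here, and "the series" means these few. Any claim that something is new, unique, unknown or untested is made for them only; others in the source may bear on it.

Of the compounds shown here, three sharing one core have been measured in a functional assay on KB cells (Homo sapiens) for cytotoxicity; on this read-out higher numbers stand for an effect only at larger amounts of compound and lower numbers for an effect already at smaller amounts. Compound 1 `COC1=C(C)C(=O)/C(=C(O)/C=C/c2cccc(OC)c2)C(=O)C1(C)C` gives 2.4 ug/mL, compound 2 `COC1=C(C)C(=O)/C(=C(O)/C=C/c2ccc(C)cc2)C(=O)C1(C)C` gives 1.9 ug/mL, and compound 3 `COC1=C(C)C(=O)/C(=C(O)/C=C/c2c(C)cc(C)cc2C)C(=O)C1(C)C` gives 1.84 ug/mL. Compound 2 lies within the usual scatter of both other compounds, so these numbers do not separate it from them.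

The next compound is compound 4 `COC1=C(C)C(=O)/C(=C(O)/C=C/c2ccco2)C(=O)C1(C)C`, in which furan-2-yl takes the place of 4-methylphenyl on a double-bonded chain carbon bound to a double-bonded chain carbon (furan-2-yl in place of 4-methylphenyl on a double-bonded chain carbon bound to a double-bonded chain carbon). Among the compounds with values here, the only measured step at this place puts 4-methylphenyl in the place of 3-methoxyphenyl and gives a 1.3-fold lower number from compound 1 to compound 2 (0.10 log units; within the scatter), which is within the scatter. Within the data shown here, no measured compound carries a five-membered aromatic ring here, so this guide is limited and the range must stay wide.

In this assay, the expected change is no larger than the scatter, and the estimated step is a 1.2-fold higher number from compound 2 to compound 4 (0.06 log units; within the scatter). The estimate for compound 4 is 2.2 ug/mL, with an expected range from 1.1 ug/mL to 4.5 ug/mL.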

Compound 4, concentration for half-maximal effect: 8.8 ug/mL
Compound 4: the middle estimate sits 4.0-fold (0.60 log units) below what was measured; measured number above the stated range.
By their numbers in this assay, from the lowest: compounds 3, 2 and 1 (each within the scatter of the next); then compound 4.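

Furan-2-yl is the first group at this place whose effect stands clear of the scatter in this assay, giving a 4.6-fold higher number from compound 2 to compound 4 (0.67 log units; beyond the scatter) and a 3.7-fold higher number from compound 1 to compound 4 (0.56 log units; beyond the scatter). The position is therefore not indifferent to what it carries: compounds 1, 2 and 3, each with a substituted six-membered aromatic ring of carbon only, lie close together, while compound 4, with its five-membered aromatic ring, needs a larger amount of compound for the same effect. No measurement at hand tells what lies behind this shift.

Compound 4 changes the ring size and brings an oxygen into the ring in a single step, so these two changes cannot be told apart. A thiophen-2-yl ring or a pyridin-3-yl ring at this place would be needed to separate them.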